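The source may hold more compounds than are shown below. What is called first, only, known or untested is meant among the compounds shown, and "the series" means these compounds.

Compound 2, with the structure `CN1CCN(c2ccc(Nc3nc(-c4cccc(NC(=O)c5ccc(C(C)(C)C)cc5)c4)sc3C(N)=O)cc2)CC1`, is the stronger of the two measured compounds. In a functional assay on Ramos cells (Homo sapiens) for antiproliferative activity, read by CCK-8 assay, with a stated time of 72 h (a higher number here means a weaker inhibitor, a lower number a stronger inhibitor), compound 2 gives 8600 nM, the lowest of the two numbers in hand. Within the data shown here, its only measured companion is compound 1, with the structure `CCOC(=O)c1sc(-c2cccc(NC(=O)c3ccccc3)c2)nc1Nc1ccc(N2CCN(C)CC2)cc1`, which in this assay gives 24800 nM; the gap between these two values lies beyond the usual scatter. Compound 1 and compound 2 differ in two places at once, so their values cannot be read as a single step.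

Compound 3, with the structure `CN1CCN(c2ccc(Nc3nc(-c4cccc(NC(=O)c5ccccc5)c4)sc3C(N)=O)cc2)CC1`, is the next compound to be measured. It differs from compound 2 by hydrogen in place of tert-butyl on an aromatic carbon. Among the measured compounds shown here, no step between measured compounds isolates this change, so the size of the step is uncertain; a loss of some potency beyond the scatter is thought more likely than a gain, because compound 2 holds the lower value at 8600 nM and the tert-butyl group is the only feature that sets it apart from the plain benzoyl of compound 1 in that position.

For compound 3 the expected step from compound 2 is a 1.9-fold higher number from compound 2 to compound 3 (0.27 log units; within the scatter). In this assay compound 3 is therefore estimated at 16000 nM, with a range from 5000 nM to 50000 nM.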

Compound 3, half-maximal inhibitory concentration: 1760 nM
Beside the measured number, compound 3's estimate is 9.1-fold (0.96 log units) above it; the measured number lies below the stated range.
By their numbers in this assay, from the lowest: compound 3; then compound 2; then compound 1.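

In this assay, the change from 4-(tert-butyl)phenyl to phenyl gives a 4.9-fold lower number from compound 2 to compound 3 (0.69 log units; beyond the scatter), a step beyond the scatter, so on this aromatic carbon hydrogen serves better than tert-butyl, at least with the carboxamide in place. The other single change, amino in place of ethoxy on a carbonyl carbon, gives a 14-fold lower number from compound 1 to compound 3 (1.15 log units; beyond the scatter), which is the larger of the two steps and separates what compound 1 and compound 2 carried together: the two changes move the number in opposite directions, so the gap between that pair hid a large gain offset in part by a loss. The compounds shown offer no measurement that explains either step.

As far as these compounds go, since only tert-butyl and hydrogen are compared on this aromatic carbon, it remains open where a methyl group, a methoxy group or a chlorine atom there would fall, and whether the step would keep its size with the ethyl ester in place of the carboxamide. On the carbonyl carbon, a methylamino or dimethylamino group or the free carboxylic acid remains an open question as well.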